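This account rests on a few compounds, and the source may have more. Where it says the series, first, only, none or still open, it means among the compounds named here.

Measured compounds:
Compound 1, `CCC(C(=O)N1CCN(c2ccc(F)cc2)CC1)N1C(=O)CCC1=O`: 25%
Compound 2, `CC(C(=O)N1CCN(c2ccc(F)cc2)CC1)N1C(=O)CCC1=O`: 50%
Compound 3, `CCC(C(=O)N1CCN(c2cccc(C(F)(F)F)c2)CC1)N1C(=O)CCC1=O`: 50%

Three compounds of one series were tested in a functional assay on the whole organism (strain Swiss) with Mus musculus as the target, in the maximal electroshock model, with a stated time of 0.5 h, at a dose of 300 mg/kg by the intraperitoneal route; on this read-out higher numbers stand for a stronger effect at the one dose given and lower numbers for a weaker effect. Compound 1 gives 25% in this assay, compound 2 gives 50% and compound 3 gives 50%. The change from compound 1 to compound 2, (hydrogen in place of methyl on a saturated chain carbon, two bonds along the chain from an amide-type nitrogen in a ring and a carbonyl carbon), made a step of a number 25 percentage points higher from compound 1 to compound 2 (beyond the scatter). Compound 3 and compound 2 stand at the same number, and together they give the two highest values of the three; compound 1 lies below both of them beyond the usual scatter. The difference between the core of compound 1 and the core of compound 3 is not broken down here.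

Compound 4, `CC(C(=O)N1CCN(c2cccc(C(F)(F)F)c2)CC1)N1C(=O)CCC1=O`, has not yet been measured in this assay. Going by the values given here, it arises from compound 3 by hydrogen in place of methyl on a saturated chain carbon, two bonds along the chain from an amide-type nitrogen in a ring and a carbonyl carbon, which is the same change as the one from compound 1 to compound 2, at the same place. Among the compounds with values here, for compound 4 a rise of a number 12 percentage points higher from compound 3 to compound 4 (beyond the scatter) is expected, a smaller step than the earlier one, because compound 3 already gives 50% and the one comparable pair rests on a single step of a number 25 percentage points higher from compound 1 to compound 2 (beyond the scatter). Compound 4 is therefore estimated at 62%, with a range from 40% to 85%.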

Compound 4, a percentage reported as activity, at one dose (the size of the read-out at that dose, not a potency): 100%
The estimate for compound 4 lay 38 percentage points below the measured number, outside the stated range (above it).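

In this assay, the change from ethyl to methyl on the chain gave a number 50 percentage points higher from compound 3 to compound 4 (beyond the scatter), so it raised the number on both cores shown and the direction carried over from the first pair to the second. The size of the step did not carry over, and the two steps stand clearly apart: the same change on two cores in this assay, a number 25 percentage points higher (beyond the scatter) from compound 1 to compound 2 and a number 50 percentage points higher (beyond the scatter) from compound 3 to compound 4, 25 percentage points apart, beyond the scatter of two such steps

Going by these compounds alone, this rests on only two pairs at one dose and one stated time, so it does not show why the step is larger on one core than on the other, nor that the same direction would hold on any further core.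

The compounds shown leave open how a longer chain such as propyl, or a branched one such as isopropyl, would behave at this saturated chain carbon, since only ethyl and methyl appear there. They also leave open whether the step would keep its direction with a chlorine atom or a methoxy group in place of the fluorine or the trifluoromethyl group, and how any of these compounds would compare at lower doses.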